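Hydroxycyclohexyl for hydroxypropyl: permeability notes

The compounds below may be only part of what the source reports. "The series", "measured", "known", "first", "only" and "open" are said of these compounds alone.

Measured compounds:
compound 1 `COc1ccc(Cn2c(-c3ccccc3)c(-c3ccccc3)c3c(=N)n([C@H]4CC[C@H](O)CC4)cnc32)cc1` – > 1000 10^-6 cm/s in an ADME assay for permeability, using PAMPA, with a stated time of 30 min, at pH 7.4 (a higher number here means that the compound crosses the layer faster, a lower number that the compound crosses the layer more slowly), a limit of the assay
compound 2 `COc1ccc(Cn2c(-c3ccccc3)c(-c3ccccc3)c3c(=N)n(CCCO)cnc32)cc1` – > 1000 10^-6 cm/s in this assay, a limit of the assay
compound 3 `Cc1c(C)n(Cc2ccccc2)c2ncn(CCCO)c(=N)c12` – 609 10^-6 cm/s in this assay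

Among the measured compounds shown here, compound 3 gives the only number in the set; the other two values are limits. Compound 1 differs from compound 2 by 4-hydroxycyclohexyl in place of 3-hydroxypropyl on an aromatic nitrogen. The step that the two limits leave unreadable from compound 2 to compound 1 cannot be read because both values sit at the limit of > 1000 10^-6 cm/s in this assay, at which 2 of the 3 values shown sit. How the core of compound 3 differs from the core of compound 2 is not broken down here.

Compound 4 `Cc1c(C)n(Cc2ccccc2)c2ncn([C@H]3CC[C@H](O)CC3)c(=N)c12` is not yet measured. It differs from compound 3 by 4-hydroxycyclohexyl in place of 3-hydroxypropyl on an aromatic nitrogen, the same change as from compound 2 to compound 1.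

For the measured compounds named here, for compound 4 in this assay the step of a 1.3-fold higher number from compound 3 to compound 4 (0.12 log units; within the scatter) is expected to be small, a guess that rests on compound 3 already sitting at 609 10^-6 cm/s with only one earlier instance of the change and that one unreadable. Compound 4 is therefore estimated at 800 10^-6 cm/s, with a range from 400 10^-6 cm/s to 1500 10^-6 cm/s, and a real chance that the assay reports only a limit.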

Compound 4, apparent permeability: < 1 10^-6 cm/s
Compound 4 was reported as a limit (the forecaster's own chance of this, stated with the estimate: 35%); middle value at least 800-fold (2.90 log units) away from the limit.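

On the core of compound 3, in this assay, 4-hydroxycyclohexyl in place of 3-hydroxypropyl on an aromatic nitrogen gives an at least 600-fold lower number from compound 3 to compound 4 (2.78 log units; beyond the scatter). Compound 4 gives < 1 10^-6 cm/s, which is a limit of the assay and not a number. This single readable step does not show whether the change carries from one core to another, because the only other instance, between compound 2 and compound 1, cannot be read with both compounds at the same limit: the limit of > 1000 10^-6 cm/s in this assay, at which 2 of the 4 values shown sit.

The compounds shown leave open whether the step in this assay follows the six-membered ring of carbon itself, the larger group as a whole, or its two defined stereocentres. Also open, as far as these compounds go, is how a longer hydroxyalkyl chain, a 4-aminocyclohexyl group or a cyclohexyl group without the hydroxyl would read on that aromatic nitrogen of the core of compound 3.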